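This account rests on a few compounds, and the source may have more. Where it says the series, first, only, none or still open, it means among the compounds named here.

Compound 1 `Cc1ccc(S(=O)(=O)N2CC[C@@H](Br)C[C@@H]2C2CCCCC2)cc1` carries a cyclohexyl group. In a functional assay on A2780 cells (Homo sapiens) for antiproliferative activity, read by sulforhodamine B assay, with a stated time of 48 h (on this read-out higher numbers stand for weaker inhibition of growth and lower numbers for stronger inhibition of growth), compound 1 gives > 100000 nM, which is a limit of the assay and not a number. Compound 2 `Cc1ccc(S(=O)(=O)N2CC[C@@H](Br)C[C@@H]2c2ccccc2)cc1` differs from it by phenyl in place of cyclohexyl on a saturated ring carbon. In this assay compound 2 gives > 100000 nM, again a limit and not a number. The step that the two limits leave unreadable from compound 1 to compound 2 cannot be sized because the limit of > 100000 nM in this assay, at which 2 of the 3 values shown sit, holds both ends. Going by the values given here, compound 3 `Cc1ccc(S(=O)(=O)N2CCC(Cl)=CC2C2CCCCC2)cc1` has a core whose difference from the core of compound 1 is not broken down here; in this assay compound 3 gives 39000 nM, the only number in the set. Compound 4 `Cc1ccc(S(=O)(=O)N2CCC(Cl)=CC2c2ccccc2)cc1` differs from compound 3 by phenyl in place of cyclohexyl on a saturated ring carbon, the same kind of change as between compound 1 and compound 2, though there the ring atom two ring bonds away bears a bromo group and here a chloro group. For compound 4 the expected step is a 1.5-fold higher number from compound 3 to compound 4 (0.19 log units; within the scatter), resting on the unreadable a step that the two limits leave unreadable from compound 1 to compound 2 in this assay and offering no direction. Compound 4 is estimated at 60000 nM.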

Compound 4, concentration for 50% growth inhibition: 17000 nM
Estimate against measurement, compound 4: 3.5-fold (0.55 log units) above, outside the stated range (below it).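

On the core of compound 3, phenyl in place of cyclohexyl gives, in this assay, a 2.3-fold lower number from compound 3 to compound 4 (0.36 log units; beyond the scatter), so on this core the change has a readable, modest size. The same change on the core of compound 1 cannot be read, so nothing shows whether the step carries over from one core to the other, in size or in direction: the limit of > 100000 nM in this assay, at which 2 of the 4 values shown sit. The series therefore offers one readable step on one core, which neither supports nor contradicts transfer between cores.

As far as these compounds go, it remains open how a longer chain in place of cyclohexyl or phenyl would behave on either core. Also open, from the compounds shown here alone, is whether an amine or a carboxylic acid on the phenyl would move the number.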